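Aryloxymethyl ketone series: replacement at the ketone-side oxygen

The compounds below may be only part of what the source reports. "The series", "measured", "known", "first", "only" and "open" are said of these compounds alone.

Compound 2 `CC(C)[C@H](NC(=O)COc1cccc2ccccc12)C(=O)N[C@@H](CC(=O)O)C(=O)COc1ccnc(C(F)(F)F)n1` stands at the lower end of the two numbers in hand: in a functional assay on Jurkat cells (Homo sapiens) for inhibition (a lower number here means a stronger inhibitor, a higher number a weaker inhibitor), compound 2 gives 37000 nM, while compound 1 `Cc1nnc(SCC(=O)[C@H](CC(=O)O)NC(=O)[C@@H](NC(=O)COc2cccc3ccccc23)C(C)C)s1` gives 190000 nM. For the measured compounds named here, the single step measured so far, a 5.1-fold lower number from compound 1 to compound 2 (0.71 log units; beyond the scatter), shows that exchange of the group on the saturated chain carbon bound to the carbonyl carbon moves the number noticeably.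

Compound 3 `CC(C)[C@H](NC(=O)COc1cccc2ccccc12)C(=O)N[C@@H](CC(=O)O)C(=O)COn1nnc2ccccc2c1=O` is not yet measured. Relative to compound 2 it carries a group of 11 heavy atoms (7 carbon, 3 nitrogen, 1 oxygen; one six-membered aromatic ring of carbon only, one six-membered aromatic ring with 3 hetero atoms) in place of a group of 10 heavy atoms (5 carbon, 2 nitrogen, 3 fluorine; one six-membered aromatic ring with 2 hetero atoms), on an oxygen on a saturated carbon. Going by the values given here, this change sits at the same place as the one measured step, so that step is the only reference, and it ran downward by a modest amount; there is no second pair to show how the entering group behaves. A further downward step of similar or smaller size is therefore expected, with wide uncertainty: for compound 3 the expected value in this assay is 20000 nM, range 5000 nM to 80000 nM, which would mean a step of a 1.9-fold lower number from compound 2 to compound 3 (0.27 log units; within the scatter).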

Compound 3, half-maximal inhibitory concentration: 137000 nM
Beside the measured number, compound 3's estimate is 6.9-fold (0.84 log units) below it, and the stated range ends below it.
By their numbers in this assay, from the lowest: compound 2; then compounds 3 and 1 (each within the scatter of the next).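

In this assay the position responds in both directions: the entering group of 11 heavy atoms, with one six-membered aromatic ring of carbon only and one with 3 hetero atoms, gives a 3.7-fold higher number from compound 2 to compound 3 (0.57 log units; beyond the scatter) and so loses what the 2-(trifluoromethyl)pyrimidin-4-yl group gained. An oxygen link alone therefore does not hold the lower number. The remaining step, a 1.4-fold lower number from compound 1 to compound 3 (0.14 log units; within the scatter) and thus within the scatter, leaves this group and the (5-methyl-1,3,4-thiadiazol-2-yl)sulfanyl group of compound 1 not told apart, and nothing at hand offers an explanation for either step.

Open, going by these compounds, is what the trifluoromethyl group itself contributes to compound 2, a question a methyl group in its place would address. Also open, on these data alone, is whether the linking atom matters apart from the ring it carries, as a phenyl group joined through oxygen and through sulfur would show.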